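The source may report more compounds than this note shows. Statements on the series, on what has been measured and on what is new or still open speak of the compounds shown alone.

Compounds measured:
compound 1 `CC1=CC[C@H](C(C)(C)NC(=S)N/N=C/c2ccc(O)cc2)CC1` — > 100000 nM
compound 2 `CC1=CC[C@H](C(C)(C)NC(=S)N/N=C/c2ccc(N(C)C)cc2)CC1` — > 100000 nM
compound 3 `COc1cc(/C=N/NC(=S)NC(C)(C)[C@H]2CC=C(C)CC2)ccc1O` — 53500 nM

In a functional assay on OVCAR-3 cells (Homo sapiens) for inhibition, read by sulforhodamine B assay, with a stated time of 48 h (on this read-out higher numbers stand for weaker inhibition of growth and lower numbers for stronger inhibition of growth), compound 1 gives > 100000 nM, which is a limit of the assay and not a number. Compound 2 likewise sits at a limit, > 100000 nM. Compound 3 gives 53500 nM. Two of the three values thus rest on (the limit of > 100000 nM in this assay, at which 2 of the 3 values shown sit), and only compound 3 shows a number, so compound 1 stands at that limit and its place relative to the others cannot be fixed beyond that.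

The move to compound 4 `CC1=CC[C@H](C(C)(C)NC(=S)N/N=C/c2ccco2)CC1` is furan-2-yl in place of 4-hydroxyphenyl on a carbon with a double bond to nitrogen. Two measured steps start from compound 1. The change a step that the two limits leave unreadable from compound 1 to compound 2 yields nothing readable. The change an at least 1.8-fold lower number from compound 1 to compound 3 (0.27 log units; that floor lies within the scatter) stays within the scatter. Going by the values given here, neither step exchanges the aromatic ring itself, so the furan-2-yl replacement has no direct precedent in this set; what the set shows is that each change so far has left growth inhibition weak, at or near the limit. Compound 4 is therefore expected to stay in the same region, with a number no higher from compound 1 to compound 4 (the limit leaves the size open) amounting to no step beyond the scatter. The estimate for compound 4 is 100000 nM, between 40000 nM and 300000 nM, with a real chance that only a limit is reported again.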

Compound 4, concentration for 50% growth inhibition: 10800 nM
Beside the measured number, compound 4's estimate is 9.3-fold (0.97 log units) above it; the whole stated range lies above it.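

Working notes on the series. In this assay, going by these compounds alone, exchanging the whole aromatic ring on the carbon with a double bond to nitrogen gives an at least 9.2-fold lower number from compound 1 to compound 4 (0.96 log units; beyond the scatter), the only readable step in this set that clears the scatter. This place therefore does respond to change: the step to compound 2 cannot be read, the step to compound 3 stays within the scatter, and neither of those two exchanges the ring itself, whereas furan-2-yl in place of 4-hydroxyphenyl moves the read-out towards stronger inhibition of growth. Compound 1 gives > 100000 nM, which is a limit of the assay and not a number, so the step is only a floor and its full size cannot be stated: the limit of > 100000 nM in this assay, at which 2 of the 4 values shown sit.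

The single exchange changes several things together, as the ring size, the ring hetero atom and the hydroxy group all differ, and the compounds shown do not separate these. Also open, from the compounds shown here alone, is whether an unsubstituted phenyl, a thiophen-2-yl or a pyridin-2-yl on the same carbon would match furan-2-yl in this assay, and whether a methyl group on the furan ring would keep the gain.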